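The compounds below may be only part of what the source reports. "The series", "measured", "known", "first", "only" and "open" are said of these compounds alone.

The measured compounds and their values are:

Compound 1, `Cc1ccnc2nc(-c3cccc(Cl)c3)cc(O)c12`, in a functional assay on SK-MEL-5 cells (Homo sapiens) for antiproliferative activity (on this read-out higher numbers stand for weaker inhibition of growth and lower numbers for stronger inhibition of growth), gives 41.7 nM.
Compound 2, `Cc1cc(C)c2c(O)cc(-c3cccc(Cl)c3)nc2n1`, in this assay gives 117 nM.
Compound 3, `Cc1ccc2c(O)cc(-c3ccc4ccccc4c3)nc2n1`, in this assay gives 3310 nM.

Compound 3 gives a higher number than both compound 1 and compound 2, so among the measured compounds it is the weakest inhibitor of growth. Compound 2 arises from compound 1 by one change, (methyl in place of hydrogen on an aromatic carbon), and that change gave a 2.8-fold higher number from compound 1 to compound 2 (0.45 log units; beyond the scatter). The unmeasured compound 4, `Cc1cc(C)c2c(O)cc(-c3ccc4ccccc4c3)nc2n1`, arises from compound 3 by the same kind of change, (methyl in place of hydrogen on an aromatic carbon). The surroundings of the place are not described in the same words: in the first case the site is next to the ring nitrogen and para to a fused ring, in the second it is ortho to a fused ring and opposite the ring nitrogen. The difference between the core of compound 1 and the core of compound 3 is not broken down here.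

Since the earlier step was a 2.8-fold higher number from compound 1 to compound 2 (0.45 log units; beyond the scatter), a step of comparable size is expected in this assay, resting on that single measured pair. Compound 4 is therefore expected to give about 9000 nM, with the likely range from 3000 nM to 25000 nM. The expected step is a 2.7-fold higher number from compound 3 to compound 4 (0.43 log units; beyond the scatter).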

Compound 4, concentration for 50% growth inhibition: 2190 nM
Compound 4: middle estimate off by 4.1-fold (0.61 log units), on the high side; the whole stated range lies above it.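

In this assay, methyl in place of hydrogen on the core of compound 3 gave a 1.5-fold lower number from compound 3 to compound 4 (0.18 log units; within the scatter), so on this core the step cannot be told apart from the ordinary spread of repeated measurements. Set beside the earlier step, the change did not carry over with the same size from one core to the other: the same change on two cores in this assay, a 2.8-fold higher number (0.45 log units; beyond the scatter) from compound 1 to compound 2 and a 1.5-fold lower number (0.18 log units; within the scatter) from compound 3 to compound 4, 4.2-fold (0.63 log units) apart, beyond the scatter of two such steps This shows that a single measured pair was a poor guide to the same change on another core, but it does not show what sets the two steps apart, since the pairs differ both in the rest of the core and in the surroundings of the methyl.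

The compounds shown leave open whether a different group at the place opposite the ring nitrogen, such as an ethyl chain, a methoxy group or an amine, would give a clearer step. They also leave open how the same methyl would behave on further cores of this series.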